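A few compounds are considered here, and "the series" means these few. Any claim that something is new, unique, unknown or untested is made for them only; others in the source may bear on it.

For the measured compounds named here, compound 2 `COc1ncc(C(F)(F)F)cc1CO[C@H]1[C@H](C(C)(C)C)[C@@H](C(=O)O)N(C(=O)[C@@H]2CCCCO2)[C@H]1c1ccccc1C(C)C` gives the lower of the two numbers measured so far in an assay on cells with Cystic fibrosis transmembrane conductance regulator variant F508del (Homo sapiens) as the target, read by voltage clamp, with a stated time of 24 h, in the presence of a further agent that is not named here; a lower number here means that less compound is needed, a higher number that more compound is needed for the effect: compound 2 gives 35 nM, while compound 1 `COc1ncc(C(F)(F)F)cc1CO[C@H]1[C@H](C(C)(C)C)[C@@H](C(=O)O)N(C(=O)[C@@H]2CCCCO2)[C@H]1c1ccccc1` gives 213 nM. Going by the values given here, the one measured step, a 6.1-fold lower number from compound 1 to compound 2 (0.78 log units; beyond the scatter), came with an isopropyl group entering in place of a hydrogen on an aromatic carbon.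

Compound 3 `COc1ncc(C(F)(F)F)cc1CO[C@H]1[C@H](C(C)(C)C)[C@@H](C(=O)O)N(C(=O)[C@@H]2CCCCO2)[C@H]1c1ccccc1C1CC1` differs from compound 2 only in that place: cyclopropyl in place of isopropyl on an aromatic carbon. Among the compounds with values here, the step of a 6.1-fold lower number from compound 1 to compound 2 (0.78 log units; beyond the scatter) bears on this change in that it shows the effect of filling that aromatic carbon with a three-carbon group, but no measured pair shows how cyclopropyl compares with isopropyl once such a group is present. With both groups holding the same count of three carbon atoms, the expected step of no change at the digits printed from compound 2 to compound 3 (within the scatter) is no larger than the scatter, in no firm direction. Compound 3 is therefore estimated at 35 nM, with a likely range from 15 nM to 90 nM.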

Compound 3, half-maximal effective concentration: 66 nM
Beside the measured number, compound 3's estimate is 1.9-fold (0.28 log units) below it; the range from low to high includes it.
By their numbers in this assay, from the lowest: compounds 2 and 3 (each within the scatter of the next); then compound 1.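

With a second group at this place, on an aromatic carbon ortho to a large group, the lower number no longer rests on isopropyl alone: in this assay, cyclopropyl in place of hydrogen gives a 3.2-fold lower number from compound 1 to compound 3 (0.51 log units; beyond the scatter). Replacing isopropyl with cyclopropyl gives a 1.9-fold higher number from compound 2 to compound 3 (0.28 log units; within the scatter), so this assay does not separate the open-chain group from the ring-bearing one, and they cannot be ranked here. Nothing measured on these compounds explains this result.

The compounds shown leave open whether a one-carbon methyl group would suffice here, or whether a longer chain such as n-butyl would keep the lower number. They also leave open how a group carrying a heteroatom, such as methoxy or an amine, would fare at this place.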